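Replacing a Carbamate with Azide: Effect on Liver Stability

The source may hold more compounds than are shown below. What is called first, only, known or untested is meant among the compounds shown, and "the series" means these compounds.

Compound 1 `CC(=O)N[C@@H]1CCN(c2cc(C)nn3c(-c4cccc(S(=O)(=O)N(C)C)c4)c(C)nc23)C1`, compound 2 `COc1ccc(-c2c(C)nc3c(N4CC[C@@H](NC(=O)Oc5cccc(C)c5)C4)cc(C)nn23)cc1OC` and compound 3 `COc1ccc(-c2c(C)nc3c(N4CC[C@@H](NC(=O)Oc5ccc6ccccc6c5)C4)cc(C)nn23)cc1OC` share one core and were all tested in an ADME assay on microsomes from liver (Mus musculus) for metabolic stability, read by LC-MS, with NADPH named in the record, with a stated time of 60 min, tested at 1 uM, in the absence of a further agent; a lower number here means that less of the compound is left, a higher number that more of the compound is left. Compound 1 reaches the limit of the assay, giving > 95%. Compound 2 likewise sits at a limit, with > 95%. Compound 3 also shows a limit, at > 95%. Because (the limit of > 95% in this assay, at which 3 of the 3 values shown sit), the step that the two limits leave unreadable from compound 2 to compound 3 cannot be read, and compound 2 stands only at a limit rather than at a number. Compound 4 `COc1ccc(-c2c(C)nc3c(N4CC[C@@H](N=[N+]=[N-])C4)cc(C)nn23)cc1OC` differs from compound 2 in one place: azido in place of ((3-methylphenoxy)carbonyl)amino on a saturated ring carbon. No measured step bears on this change; the only step shown is unreadable. Compound 4 is therefore expected to remain at the same limit, with an estimated step of a number no higher from compound 2 to compound 4 (the limit leaves the size open). The estimate for compound 4 is 95%, expected to lie between 85% and 100%.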

Compound 4, percent of the compound remaining: > 95%
Compound 4: a limit, no number; the forecaster's own chance of this, stated with the estimate: 70%; the middle value sits exactly at the limit.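

In this assay compound 4 gives > 95%, which is a limit and not a number. No step from compound 2 to compound 4 can be read, because the result sits at that limit: the limit of > 95% in this assay, at which 4 of the 4 values shown sit.

The compounds shown leave open how much of each compound truly remains, and so whether azido and ((3-methylphenoxy)carbonyl)amino differ at all here.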